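This account rests on a few compounds, and the source may have more. Where it says the series, first, only, none or still open, it means among the compounds named here.

Compound 1 `CO[C@H]1CC[C@H]2CCN(C)[C@H]2C1` gives only a limit, > 300000 nM, in an assay on HEK293 cells for antagonist activity at Nicotinic acetylcholine receptor alpha-4/beta-2 (Mus musculus), read by FLIPR, using a membrane potential dye; on this read-out lower numbers stand for stronger inhibition and higher numbers for weaker inhibition.
Compound 2 `CO[C@H]1CC=C2CCN(C)[C@H]2C1` gives 30000 nM in this assay.
Compound 3 `CCO[C@H]1CC=C2CCN(C)[C@H]2C1` gives only a limit, > 300000 nM, in this assay.

Compound 3 thus sits at the limit of > 300000 nM in this assay, at which 2 of the 3 values shown sit; no number is known for it, only the limit. For the measured compounds named here, the one measured step that leads to it is an at least 10-fold higher number from compound 2 to compound 3 (1.00 log units; beyond the scatter). Compound 4 `COCCO[C@H]1CC=C2CCN(C)[C@H]2C1` differs from compound 3 by methoxy in place of hydrogen on a saturated chain carbon, two bonds along the chain from an oxygen on a saturated carbon; the same difference, cut one bond further out, reads ethoxy to 2-methoxyethoxy. The chain on the oxygen is thus lengthened again, in the same sense as an at least 10-fold higher number from compound 2 to compound 3 (1.00 log units; beyond the scatter). In this assay no step beyond the scatter is expected, and the value is expected to stay at the limit, the estimated step being a step that the limit leaves unreadable from compound 3 to compound 4. Compound 4 is estimated at 400000 nM, range 100000 nM to 2000000 nM.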

Compound 4, half-maximal inhibitory concentration: > 300000 nM
Compound 4: only a limit was reported (the forecaster's own chance of this, stated with the estimate: 80%); the middle value is on the limit's open side.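

In this assay, the longer 2-methoxyethoxy chain on this oxygen also ends with an at least 10-fold higher number from compound 2 to compound 4 (1.00 log units; beyond the scatter), so the loss seen with ethoxy is not undone by an oxygen within the chain. Compound 4 gives only a limit, > 300000 nM. Going by these compounds, the step from ethoxy to 2-methoxyethoxy cannot be read, as both ends are limits, so the size of any change from this methoxy remains unknown.

Among the groups on this oxygen, only methoxy gives a number. On these data alone, whether a 2-hydroxyethyl chain, or a chain ending in an amine or a carboxylic acid, would give a number here remains open.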